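The source may report more compounds than this note shows. Statements on the series, on what has been measured and on what is new or still open speak of the compounds shown alone.

Compound 1 `O=C1CCc2ccccc2N1CCCCN1CCN(C2CCCCC2)CC1` and compound 2 `O=C1CCc2ccccc2N1CCCCN1CCN(c2ccc(F)cc2)CC1` share a core and differ only on the ring amine nitrogen. In an assay on cell membranes for displacement of a labelled ligand from Sigma non-opioid intracellular receptor 1 (Cavia porcellus), read by scintillation counting, with a stated time of 120 min (on this read-out lower numbers stand for stronger inhibition and higher numbers for weaker inhibition), compound 1 gives 21 nM, and compound 2 gives 16 nM; the change a 1.3-fold lower number from compound 1 to compound 2 (0.12 log units; within the scatter) is within the scatter, so compound 2 stands with the lowest number of the two without a real separation. Compound 3 `O=C1CCc2ccccc2N1CCCCN1CCN(c2ccccn2)CC1` carries the change (pyridin-2-yl in place of 4-fluorophenyl on an amine nitrogen in a ring). For the measured compounds named here, only that one measured step bears on it, and it was small, so a step beyond the scatter from compound 2 to compound 3 is not expected; the step expected is a 1.8-fold higher number from compound 2 to compound 3 (0.24 log units; within the scatter). Compound 3 is expected at 28 nM, within 8 nM to 110 nM.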

Compound 3, inhibition constant: 120 nM
Estimate against measurement, compound 3: 4.3-fold (0.63 log units) below; the whole stated range lies below it.
By their numbers in this assay, from the lowest: compounds 2 and 1 (each within the scatter of the next); then compound 3.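

In this assay, pyridin-2-yl in place of 4-fluorophenyl gives a 7.5-fold higher number from compound 2 to compound 3 (0.88 log units; beyond the scatter), and pyridin-2-yl in place of cyclohexyl gives a 5.7-fold higher number from compound 1 to compound 3 (0.76 log units; beyond the scatter). The amine nitrogen in the ring had shown no real separation between its two earlier groups, so this position is not indifferent to the group it carries. Nothing measured here accounts for this change. The compounds shown leave open whether the higher number follows the ring nitrogen of pyridin-2-yl or the absence of the 4-fluorophenyl group. Plain phenyl and pyridin-4-yl at this position would bear on that question.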